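Thiophene Replaces Bromine on a Pyridine Urea

The source may report more compounds than this note shows. Statements on the series, on what has been measured and on what is new or still open speak of the compounds shown alone.

Compound 1 `CC(=O)c1cccc(NC(=O)NC2CCN(CC3=CC[C@H]4C[C@@H]3C4(C)C)CC2)c1` and compound 2 `CC1(C)[C@H]2CC=C(CN3CCC(NC(=O)Nc4cncc(Br)c4)CC3)[C@@H]1C2` share the same core and urea linkage; they differ only in the aromatic ring attached to one urea nitrogen. In a functional assay on CHO cells for antagonist activity at C-X-C chemokine receptor type 3 (Homo sapiens), read by GTPgammaS binding (on this read-out higher numbers stand for weaker inhibition and lower numbers for stronger inhibition), compound 1 gives 258 nM, while compound 2 gives 171 nM. Among the measured compounds shown here, the only measured step, a 1.5-fold lower number from compound 1 to compound 2 (0.18 log units; within the scatter), stays within the scatter, so compound 2 stands beside compound 1 on these numbers and neither can be called the stronger inhibitor.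

Compound 3 `CC1(C)[C@H]2CC=C(CN3CCC(NC(=O)Nc4cncc(-c5ccsc5)c4)CC3)[C@@H]1C2` arises from compound 2 by one change: thiophen-3-yl in place of bromo on an aromatic carbon. For the measured compounds named here, no measured step addresses this kind of change; the single step known exchanged the whole aromatic ring rather than a group on it, and was within the scatter anyway, so no direction can be inferred from the data. For compound 3 in this assay the expected value is 150 nM, with a range from 40 nM to 600 nM. This estimate implies a step of a 1.1-fold lower number from compound 2 to compound 3 (0.06 log units; within the scatter), expected to remain within the scatter.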

Compound 3, inhibition constant: 107 nM
Beside the measured number, compound 3's estimate is 1.4-fold (0.15 log units) above it; the range from low to high includes it.
By their numbers in this assay, from the lowest: compounds 3, 2 and 1 (each within the scatter of the next, the first and the last beyond it).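

Compound 3 shows that this position, two atoms from the ring nitrogen, can carry a whole thiophen-3-yl ring of 5 heavy atoms in place of the single heavy atom of bromo without leaving the scatter: this assay gives a 1.6-fold lower number from compound 2 to compound 3 (0.20 log units; within the scatter) for this exchange. The earlier step replaced the entire aromatic ring on the urea, whereas this one alters only a group on that ring, and neither compound here can be called the stronger inhibitor. Nothing measured here explains this result.

The compounds shown leave open whether an amine, a carboxylic acid or a longer alkyl chain at this position would stay within the scatter of bromo and thiophen-3-yl. They also leave open whether thiophen-2-yl or a plain phenyl ring would do the same.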